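Methyl for Chloro on the Phenoxy Ring of Compound 1

The source may report more compounds than this note shows. Statements on the series, on what has been measured and on what is new or still open speak of the compounds shown alone.

Compound 1 `N#Cc1ccc(Nc2nc(Oc3ccccc3Cl)c3ccccc3n2)cc1` stands at the toxic end of the three measured compounds in an ADME assay on MT4 cells (Homo sapiens) for cytotoxicity, read by MTT assay, with a stated time of 4 days (on this read-out lower numbers stand for higher toxicity in this test and higher numbers for lower toxicity in this test), where compound 1 gives 38000 nM. Compound 2 `COc1ccccc1Oc1nc(Nc2ccc(C#N)cc2)nc2ccccc12` gives 150000 nM, and compound 3 `N#Cc1ccc(Nc2nc(Oc3ccc(Cl)cc3)c3ccccc3n2)cc1` gives 198000 nM. Both steps away from compound 1 lie beyond the scatter, whereas compound 2 and compound 3 stand within the scatter of each other, so no order between those two can be read.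

Compound 4 `Cc1ccccc1Oc1nc(Nc2ccc(C#N)cc2)nc2ccccc12` differs from compound 1 in one place: methyl in place of chloro on an aromatic carbon. For the measured compounds named here, two measured steps bear on this change, since both alter the same chloro on the same ring. Methoxy in place of chloro produced a 3.9-fold higher number from compound 1 to compound 2 (0.60 log units; beyond the scatter), and 4-chlorophenyl in place of 2-chlorophenyl produced a 5.2-fold higher number from compound 1 to compound 3 (0.72 log units; beyond the scatter). Every recorded change to this chloro has therefore raised the number by a modest amount, and methyl is a single-heavy-atom group of the same kind as the chloro it replaces, so the author expects a smaller shift than either of those, though in the same direction.

For compound 4 the author expects a 1.8-fold higher number from compound 1 to compound 4 (0.27 log units; within the scatter). Compound 4 is estimated at 70000 nM, with a range from 30000 nM to 200000 nM.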

Compound 4, half-maximal cytotoxic concentration: 355000 nM
Estimate against measurement, compound 4: 5.1-fold (0.71 log units) below; the measured number lies above the stated range.
By their numbers in this assay, from the lowest: compound 1; then compounds 2, 3 and 4 (each within the scatter of the next, the first and the last beyond it).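

In this assay the step of a 9.3-fold higher number from compound 1 to compound 4 (0.97 log units; beyond the scatter) shows that exchanging the chloro for methyl, with the heavy-atom count at this place unchanged and no hydrogen-bond donor or acceptor entering or leaving, is enough to move the number well beyond the scatter. The position also separates the two groups that replace chloro here, since a 2.4-fold higher number from compound 2 to compound 4 (0.37 log units; beyond the scatter) lies beyond the scatter, whereas a 1.8-fold higher number from compound 3 to compound 4 (0.25 log units; within the scatter) lies within it, so no order can be read between those two compounds. No supporting finding is available to account for the behaviour of methyl at this position.

From the compounds shown here alone, what remains open is whether the low number of compound 1 belongs to chloro alone or extends to other halogens, such as fluoro or bromo, on the same aromatic carbon. Going by these compounds, it is equally open how a longer chain such as ethyl, or an amine or a hydroxyl in that place, would stand against methyl and methoxy in this assay on this shared core.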